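Adding Fluorine to Compound 3: What to Expect

The source may report more compounds than this note shows. Statements on the series, on what has been measured and on what is new or still open speak of the compounds shown alone.

Of the compounds shown here, three have so far been measured in a functional assay on WiDr cells (Homo sapiens) for inhibition, read by sulforhodamine B assay, with a stated time of 48 h; on this read-out higher numbers stand for weaker inhibition of growth and lower numbers for stronger inhibition of growth. Compound 1 `CC(=O)OC/C(=C\C1CCCCC1)C(=O)c1ccccc1` gives 21000 nM. Compound 2 `CC(=O)OC/C(=C\c1ccc(Cl)cc1)C(=O)c1ccc(Cl)cc1` gives 18000 nM. Compound 3 `C=C(C/C(=C\c1ccccc1)C(=O)c1ccccc1)C(=O)c1ccccc1` gives 18000 nM. On these numbers compound 3 is level with compound 2 at the digits shown, the two together giving the lowest readings of the three, and its gap to compound 1 also lies within the usual scatter of repeated measurements, so this assay does not separate the three.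

Compound 4 `C=C(C/C(=C\c1ccc(F)cc1)C(=O)c1ccccc1)C(=O)c1ccccc1` has not been measured. It differs from compound 3 in one place: fluoro in place of hydrogen on an aromatic carbon. Among the compounds with values here, no two measured compounds differ in only a single place, so no measured step shows how such a swap plays out. What can be said is that compound 2, which carries chloro on two aromatic rings, gives 18000 nM, level with compound 3, so a halogen on an aromatic ring has not moved the reading here. The expected step is no change at the digits printed from compound 3 to compound 4 (within the scatter), small and in no clear direction beyond the scatter. Compound 4 is therefore estimated at 18000 nM, with a range from 9000 nM to 36000 nM.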

Compound 4, concentration for 50% growth inhibition: 19000 nM
Compound 4: the middle estimate sits 1.1-fold (0.02 log units) below what was measured; the measured number falls inside the stated range.
By their numbers in this assay, from the lowest: compounds 2, 3, 4 and 1 (each within the scatter of the next).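

In this assay, within the data shown here, the swap of phenyl to 4-fluorophenyl gives a 1.1-fold higher number from compound 3 to compound 4 (0.02 log units; within the scatter) and so provides the first direct reading of a single change. At this aromatic carbon, para to a large group, fluoro and hydrogen cannot be told apart on this read-out, something compound 2 could not show, since it differs from compound 3 in more than one place. No supporting measurement is available to explain this result.

As far as these compounds go, whether an amine, a carboxylic acid or a longer chain such as butyl at this position would separate from hydrogen remains open. So does whether fluoro placed elsewhere on this ring, or on one of the other rings, would behave as it does here.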